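Swapping a methoxy for a trifluoromethyl on the rhodanine ring

The compounds below may be only part of what the source reports. "The series", "measured", "known", "first", "only" and "open" are said of these compounds alone.

Measured so far:
compound 1, `Cc1cc(/C=C2\SC(=S)N(c3ccccc3)C2=O)c(C)n1-c1cccc(-c2nnn[nH]2)c1`: 61000 nM
compound 2, `COc1cccc(N2C(=O)/C(=C/c3cc(C)n(-c4cccc(-c5nnn[nH]5)c4)c3C)SC2=S)c1`: 40600 nM
compound 3, `COc1ccc(N2C(=O)/C(=C/c3cc(C)n(-c4cccc(-c5nnn[nH]5)c4)c3C)SC2=S)cc1`: 87000 nM

All three share one core and differ only in the aryl group on the amide-type nitrogen in a ring. In an ADME assay on MT2 cells (Homo sapiens) for cytotoxicity, read by XTT assay, with a stated time of 4 days (a lower number here means that less compound is tolerated, a higher number that more compound is tolerated), compound 3 gives the highest of the three numbers, yet its distance to compound 1 is small, a 1.4-fold higher number from compound 1 to compound 3 (0.15 log units; within the scatter), and only its distance to compound 2 counts as a real step, a 2.1-fold higher number from compound 2 to compound 3 (0.33 log units; beyond the scatter).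

Compound 4, `Cc1cc(/C=C2\SC(=S)N(c3ccc(C(F)(F)F)cc3)C2=O)c(C)n1-c1cccc(-c2nnn[nH]2)c1`, has not been measured. It differs from compound 3 in one place: trifluoromethyl in place of methoxy on an aromatic carbon. For the measured compounds named here, no measured step involves a trifluoromethyl, so nothing speaks directly to this change. The measured steps, a 1.5-fold lower number from compound 1 to compound 2 (0.18 log units; within the scatter) and a 1.4-fold higher number from compound 1 to compound 3 (0.15 log units; within the scatter), show that a methoxy added at either position moved this assay little. On that basis, for compound 4 a step of about a 1.2-fold lower number from compound 3 to compound 4 (0.09 log units; within the scatter) is expected, that is, no change beyond the scatter. The estimate for compound 4 is 70000 nM, with a range from 30000 nM to 150000 nM.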

Compound 4, half-maximal cytotoxic concentration: 27100 nM
Compound 4: middle estimate off by 2.6-fold (0.41 log units), on the high side; the measured number lies below the stated range.
By their numbers in this assay, from the lowest: compounds 4, 2, 1 and 3 (each within the scatter of the next, the first and the last beyond it).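

Going from 4-methoxyphenyl to 4-(trifluoromethyl)phenyl in this assay gives the largest step so far (a 3.2-fold lower number from compound 3 to compound 4 (0.51 log units; beyond the scatter)), so the identity of the group at this place matters, and a single swap on the aromatic carbon can move the number beyond the scatter. Trifluoromethyl also separates from the unsubstituted phenyl (a 2.3-fold lower number from compound 1 to compound 4 (0.35 log units; beyond the scatter)), which neither methoxy did, yet it cannot be told apart from the 3-methoxyphenyl group (a 1.5-fold lower number from compound 2 to compound 4 (0.18 log units; within the scatter)), so the lower end of this small set is shared by two different groups. Nothing measured here explains the change. From the compounds shown here alone, it remains open whether the lower number is particular to trifluoromethyl, or whether a chlorine, a nitrile or an amine at the same place would behave alike. Going by these compounds, a trifluoromethyl in the position held by the methoxy of compound 2 also remains untested here.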